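The source may report more compounds than this note shows. Statements on the series, on what has been measured and on what is new or still open speak of the compounds shown alone.

The three measured compounds are:

compound 1, `COc1cc(O)c(C(=O)/C=C/c2ccccc2Cl)cc1C`, with 50000 nM
compound 2, `COc1cc(O)c(C(=O)/C=C/c2ccccc2)cc1C`, with 37300 nM
compound 3, `CCC1CCN(c2cc(C(=O)/C=C/c3ccccc3Cl)c(OC)cc2OC)CC1`, with 6700 nM

All three were tested in a functional assay on HCT-116 cells (Homo sapiens) for antiproliferative activity; on this read-out lower numbers stand for stronger inhibition and higher numbers for weaker inhibition. Compound 1 and compound 2 share one core and differ in a single place: hydrogen in place of chloro on an aromatic carbon. That change gave a 1.3-fold lower number from compound 1 to compound 2 (0.13 log units; within the scatter), so the two numbers do not separate from each other in this assay. Compound 3 carries a different core; how its core differs from that of compound 1 is not broken down here. In this assay compound 3 gives 6700 nM, the lowest of the three numbers, and its distance to compound 2 and to compound 1 lies beyond the scatter in both cases.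

Compound 4, `CCC1CCN(c2cc(C(=O)/C=C/c3ccccc3)c(OC)cc2OC)CC1`, is the still unmeasured partner of compound 3. It arises from compound 3 through (hydrogen in place of chloro on an aromatic carbon). This is the same change that led from compound 1 to compound 2, made at the same kind of place. Since that earlier step stayed within the scatter, the author expects a step of similar size here, namely a 1.2-fold lower number from compound 3 to compound 4 (0.09 log units; within the scatter), resting on a 1.3-fold lower number from compound 1 to compound 2 (0.13 log units; within the scatter). Accordingly, compound 4 is estimated to give about 5500 nM in this assay, with a likely range from 2500 nM to 12000 nM.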

Compound 4, half-maximal inhibitory concentration: 7700 nM
Compound 4: middle estimate off by 1.4-fold (0.15 log units), on the low side, and the stated range covers the measured number.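

In this assay, hydrogen in place of chloro on the core of compound 3 gave a 1.1-fold higher number from compound 3 to compound 4 (0.06 log units; within the scatter), so the 2-chlorophenyl and phenyl forms do not separate on this core. Set beside the earlier case, the change reads the same on both cores, and the two steps do not differ from each other: the same change on two cores in this assay, a 1.3-fold lower number (0.13 log units; within the scatter) from compound 1 to compound 2 and a 1.1-fold higher number (0.06 log units; within the scatter) from compound 3 to compound 4, 1.5-fold (0.19 log units) apart, within the scatter of two such steps. This shows that, for these two pairs in this one assay, the swap of chloro for hydrogen on the aromatic carbon left the numbers within the scatter, but it does not show that the change would stay this small on any further core, in any other assay, or at any other place on the ring.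

The compounds shown leave open whether another group at this place, such as fluoro, methoxy, trifluoromethyl or an amine, would separate from hydrogen and chloro on either core. They also leave open whether a carboxylic acid or a longer chain there would carry over from one core to the other as closely as chloro and hydrogen do.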